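This account rests on a few compounds, and the source may have more. Where it says the series, first, only, none or still open, it means among the compounds named here.

Of the compounds shown here, three that share one core have been tested so far. Compound 1 `COc1ccc2[nH]c(C(=O)Cc3cccnc3)cc2c1` in an assay on isolated protein for inhibition of Indoleamine 2,3-dioxygenase 1 (Homo sapiens), read by spectrophotometry (a higher number here means a weaker inhibitor, a lower number a stronger inhibitor), gives 49000 nM. Compound 2 `COc1ccc2[nH]c(C(=O)Cc3cccnc3)cc2c1O` gives 63000 nM in this assay, and compound 3 `O=C(Nc1cccnc1)c1cc2ccccc2[nH]1` gives 94000 nM. Compound 1 has the lowest of the three numbers, but each of the other two lies within the usual scatter of it, so the three cannot be told apart. Among the measured compounds shown here, the one step between compounds that differ in a single place, a 1.3-fold higher number from compound 1 to compound 2 (0.11 log units; within the scatter), is a hydroxy in place of hydrogen on an aromatic carbon and stays within the scatter.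

Compound 4 `Cc1ccc2[nH]c(C(=O)Cc3cccnc3)cc2c1` differs from compound 1 by methyl in place of methoxy on an aromatic carbon. For the measured compounds named here, no measured step swaps a methoxy for a methyl; the only measured step touches a different place on the same ring and produced no change beyond the scatter. A step of no clear size beyond the scatter is therefore expected here as well, no change at the digits printed from compound 1 to compound 4 (within the scatter). Compound 4 is expected to give about 49000 nM in this assay, within a range from 20000 nM to 120000 nM.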

Compound 4, half-maximal inhibitory concentration: 87000 nM
The estimate for compound 4 lay 1.8-fold (0.25 log units) below the measured number; the measured number falls inside the stated range.
By their numbers in this assay, from the lowest: compounds 1, 2, 4 and 3 (each within the scatter of the next).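

At this position, on an aromatic carbon of the six-membered ring of carbon only, the methoxy can be replaced by a methyl, giving a 1.8-fold higher number from compound 1 to compound 4 (0.25 log units; within the scatter) in this assay. This swap removes one heavy atom and the group's one hydrogen-bond acceptor, yet the result cannot be told apart from no change, so these compounds give no sign that this acceptor matters for the number read here. Nothing available bears on the reason for this result.

From the compounds shown here alone, both groups tested here are small, so it stays open whether an amine, a carboxylic acid or a longer chain such as butoxy at this position would move the number beyond the scatter. Going by these compounds, it is also open whether plain hydrogen there would leave the number where it is.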